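The source may hold more compounds than are shown below. What is called first, only, known or untested is meant among the compounds shown, and "the series" means these compounds.

Measured compounds and their values:
- compound 1 `COc1c(N2CC[C@@H](CN)C2)c(F)cc2c(=O)c(C(=O)O)cn(Cc3cc(-c4ccccc4)no3)c12`: 178000 nM
- compound 2 `NC[C@@H]1CCN(c2cc3c(cc2F)c(=O)c(C(=O)O)cn3Cc2cc(-c3ccccc3)no2)C1`: 58300 nM
- compound 3 `CNCCCCNc1c(F)cc2c(=O)c(C(=O)O)cn(Cc3ccc(-c4ccccc4)cc3)c2c1OC`: > 200000 nM

In an assay on isolated protein for inhibition of DNA topoisomerase 1 (Homo sapiens), with a stated time of 15 min (a higher number here means a weaker inhibitor, a lower number a stronger inhibitor), compound 1 gives 178000 nM. Compound 2 differs from compound 1 by hydrogen in place of methoxy on an aromatic carbon, and in this assay compound 2 gives 58300 nM; the step is a 3.1-fold lower number from compound 1 to compound 2 (0.48 log units; beyond the scatter). Compound 3 is a different core; the difference between the core of compound 3 and that of compound 1 is not broken down here. For compound 3 this assay reports only a limit, > 200000 nM, as shown by the limit of > 200000 nM in this assay, at which 1 of the 3 values shown sits.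

Compound 4 `CNCCCCNc1cc2c(cc1F)c(=O)c(C(=O)O)cn2Cc1ccc(-c2ccccc2)cc1` is not yet measured. It differs from compound 3 by hydrogen in place of methoxy on an aromatic carbon. Among the measured compounds shown here, this is the same kind of change as the one from compound 1 to compound 2, though the place differs: in compound 1 the methoxy sits ortho to a 3-(aminomethyl)pyrrolidin-1-yl group, in compound 3 ortho to a (4-(methylamino)butyl)amino group. For compound 4 the expected step is an at least 1.3-fold lower number from compound 3 to compound 4 (0.12 log units; that floor lies within the scatter), resting on the earlier step of a 3.1-fold lower number from compound 1 to compound 2 (0.48 log units; beyond the scatter), while compound 3 starts from a limit. Compound 4 is therefore estimated at 150000 nM, with a range expected from 50000 nM to 400000 nM.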

Compound 4, half-maximal inhibitory concentration: 88300 nM
Compound 4: middle estimate off by 1.7-fold (0.23 log units), on the high side; the measured number falls inside the stated range.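

Swapping methoxy for hydrogen gives a lower number on both cores in this assay, and on the second core the result is an at least 2.2-fold lower number from compound 3 to compound 4 (0.35 log units; beyond the scatter). This shows that the direction of the change carried over between these two pairs, but not that its size did, and two pairs do not make a rule for the whole series: the same change on two cores in this assay, a 3.1-fold lower number (0.48 log units; beyond the scatter) from compound 1 to compound 2 and an at least 2.2-fold lower number (0.35 log units; beyond the scatter) from compound 3 to compound 4; the limit leaves it open whether they differ. On these data alone, the starting point on the second core is a limit of the assay for compound 3, not a number, so the true size of that step stays unknown: the limit of > 200000 nM in this assay, at which 1 of the 4 values shown sits.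

The compounds shown leave open what other groups in this place, such as ethoxy, chloro or an amine, would do to the number. They also leave open whether the step would hold if the carboxylic acid shared by these compounds were replaced by an amide.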